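The source may hold more compounds than are shown below. What is called first, only, known or untested is meant among the compounds shown, and "the series" means these compounds.

Measured so far:
Compound 1, `N#CC1=C(NC(=O)c2ccccc2)N(c2ccc(S(N)(=O)=O)cc2)C2=C(C(=O)CCC2)C1c1ccc(Cl)cc1Cl`, gives 50% in a functional assay on Ehrlich cells (Mus musculus) for cytotoxicity, read by trypan blue exclusion, with a stated time of 2 h, tested at 10 ug/mL; on this read-out lower numbers stand for a weaker effect and higher numbers for a stronger effect at the one concentration tested.
Compound 2, `NC1=C(C(=O)O)C(c2ccc(Cl)cc2Cl)C2=C(CCCC2=O)N1c1ccc(S(N)(=O)=O)cc1`, gives 0% in this assay.

Of these two numbers compound 1 stands highest, and compound 2 lies far lower, a gap beyond the usual scatter. Compound 3, `CC(=O)CC(=O)NC1=C(C#N)C(c2ccc(Cl)cc2Cl)C2=C(CCCC2=O)N1c1ccc(S(N)(=O)=O)cc1`, has not yet been measured in this assay. It differs from compound 1 in one place: 2-oxopropyl in place of phenyl on a carbonyl carbon. Among the compounds with values here, no measured pair shows how such a change acts here, so no shift beyond the scatter is assumed in either direction. The expected step is a number 5 percentage points lower from compound 1 to compound 3 (within the scatter). Compound 3 is estimated at 45%, within a range from 20% to 70%.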

Compound 3, a percentage reported as activity, at one concentration (the size of the read-out at that concentration, not a potency): 40%
Estimate against measurement, compound 3: 5 percentage points above; low and high end bracket the measured number.
By their numbers in this assay, from the lowest: compound 2; then compounds 3 and 1 (each within the scatter of the next).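

Putting 2-oxopropyl in place of phenyl on a carbonyl carbon gives a number 10 percentage points lower from compound 1 to compound 3 (within the scatter) in this assay. At this place, then, the six-membered aromatic ring can give way to an open chain carrying a hydrogen-bond acceptor with no shift past the usual scatter. No measured property bears on this result. Still open, going by these compounds, is whether an amine or a longer chain on the same carbonyl carbon would keep the read-out in this range, or whether only some groups would.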